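A few compounds are considered here, and "the series" means these few. Any claim that something is new, unique, unknown or untested is made for them only; others in the source may bear on it.

Compounds measured so far:
- compound 1, `CC(C)C[C@H](NC(=O)N1CCOCC1)C(=O)N[C@H](C#N)CCc1ccccc1`: 47 nM
- compound 2, `CC(C)C[C@H](NC(=O)N1CCOCC1)C(=O)N[C@H](C)CCc1ccccc1`: > 339000 nM
- compound 3, `CC(C)C[C@H](NC(=O)N1CCOCC1)C(=O)N[C@H](C#N)COCc1ccccc1Cl`: 9 nM

In an assay for inhibition of cathepsin S (Homo sapiens) (a lower number here means a stronger inhibitor, a higher number a weaker inhibitor), compound 1 gives 47 nM, the highest of the two plain numbers here; compound 3, at 9 nM, sits a 5.2-fold lower number from compound 1 to compound 3 (0.72 log units; beyond the scatter). The value of compound 2 is a limit of the assay, at the limit of > 339000 nM in this assay, at which 1 of the 3 values shown sits, so it is not a number; the step of an at least 7200-fold higher number from compound 1 to compound 2 (3.85 log units; beyond the scatter) is known only as a bound.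

The next compound, compound 4, `CC(C)[C@H](NC(=O)N1CCOCC1)C(=O)N[C@H](C#N)CCc1ccccc1`, keeps the nitrile and the core of compound 1 and changes only one place: isopropyl in place of isobutyl on a saturated chain carbon bound to an amide-type nitrogen and a carbonyl carbon. Neither measured step touches this position. The step to compound 2 concerned the nitrile, which compound 4 retains, so its large loss does not apply; the step to compound 3 concerned the other end of the molecule. Within the data shown here, with no comparable step, the expectation for compound 4 rests on the change being small and the rest of compound 1 intact. Compound 4 is therefore expected to give about 110 nM, within 30 nM to 450 nM, a step of a 2.3-fold higher number from compound 1 to compound 4 (0.37 log units; beyond the scatter) that may well lie within the scatter.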

Compound 4, half-maximal inhibitory concentration: 6000 nM
Beside the measured number, compound 4's estimate is 55-fold (1.74 log units) below it; measured number outside the range, above it.
By their numbers in this assay, from the lowest: compound 3; then compound 1; then compound 4. At a limit, above all of these: compound 2.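

In this assay, among these compounds, replacing isobutyl with isopropyl on the saturated chain carbon bound to an amide-type nitrogen and a carbonyl carbon gives a 130-fold higher number from compound 1 to compound 4 (2.11 log units; beyond the scatter), so this position, untouched by the earlier steps, responds strongly to the loss of a single carbon. Compound 4 keeps the nitrile, which shows that the nitrile alone does not hold the number low, and the step is larger than the one at the other end of the molecule, a 5.2-fold lower number from compound 1 to compound 3 (0.72 log units; beyond the scatter). The data shown give no cause for this loss.

The compounds shown leave open how a longer chain, a cyclohexylmethyl group or a benzyl group at this place would compare with isobutyl. They also leave open whether the lower number seen with the (2-chlorobenzyl)oxy group of compound 3 would persist with isopropyl in this place.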